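The source may report more compounds than this note shows. Statements on the series, on what has been measured and on what is new or still open speak of the compounds shown alone.

Measured compounds:
compound 1 `Cc1noc(C)c1S(=O)(=O)N1CCC(N2CCC(C)CC2)CC1`, > 5000 nM
compound 2 `Cc1cc(C)c(S(=O)(=O)N2CCC(N3CCC(CCC#N)CC3)CC2)c(C)c1`, > 5000 nM

In a functional assay on DLD-1 cells (Homo sapiens) for antiproliferative activity, read by CellTiter-Glo, with a stated time of 72 h (a higher number here means a weaker inhibitor, a lower number a stronger inhibitor), compound 1 returns only a limit, > 5000 nM. In this assay compound 2 likewise returns only a limit, > 5000 nM. Among the measured compounds shown here, compound 2 thus stands at the limit of > 5000 nM in this assay, at which 2 of the 2 values shown sit, and no measured step frames it. Compound 3 `Cc1cc(C)c(S(=O)(=O)N2CCC(N3CCC(Cc4ccccc4F)CC3)CC2)c(C)c1` differs from compound 2 by 2-fluorophenyl in place of cyanomethyl on a saturated chain carbon bound to a saturated ring carbon. For the measured compounds named here, no step among measured compounds bears on this change. The step from compound 2 to compound 3 is expected at an at least 1.2-fold lower number from compound 2 to compound 3 (0.09 log units; that floor lies within the scatter), leaning towards stronger inhibition, though another result at the limit remains about as likely. For compound 3 the estimate is 4000 nM, between 800 nM and 20000 nM.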

Compound 3, half-maximal inhibitory concentration: 74 nM
For compound 3 the middle estimate is 54-fold (1.73 log units) above the measured one; the whole stated range lies above it.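

In this assay, 2-fluorophenyl in place of cyanomethyl on a saturated chain carbon bound to a saturated ring carbon gives an at least 67-fold lower number from compound 2 to compound 3 (1.82 log units; beyond the scatter). Compound 3 is the only compound shown with a value that is not a limit, so a change at this place alone can bring measurable antiproliferative activity to the shared core. The step is a floor and not a full size, since compound 2 gives only a limit: the limit of > 5000 nM in this assay, at which 2 of the 3 values shown sit.

As far as these compounds go, whether the gain needs the fluorine or only the aromatic ring stays open. An unsubstituted phenyl or a pyridyl ring at this place would separate the two.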